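Swapping a Bromophenyl for a Methoxyphenyl on a Shared Core

The compounds below may be only part of what the source reports. "The series", "measured", "known", "first", "only" and "open" are said of these compounds alone.

Compound 3 `Brc1ccc(-c2cn3ccnc3c(-c3ccc4ncn(C5CCCCC5)c4c3)n2)cc1` carries a 4-bromophenyl group on the shared core. In a functional assay on NCI-H226 cells (Homo sapiens) for inhibition, read by sulforhodamine B assay, with a stated time of 48 h, tested at 10 uM (a lower number here means less inhibition, a higher number more inhibition at the concentration tested (going by the name of the read-out)), compound 3 gives 23.3%, level with compound 2 `Fc1ccc(-c2cn3ccnc3c(-c3ccc4ncn(C5CCCCC5)c4c3)n2)cc1` at 23.3%; together these are the lowest of three numbers, while compound 1 `c1ccc(-c2cn3ccnc3c(-c3ccc4ncn(C5CCCCC5)c4c3)n2)cc1` gives 33.9%. The measured steps are a number 10.6 percentage points lower from compound 1 to compound 2 (beyond the scatter), a number 10.6 percentage points lower from compound 1 to compound 3 (beyond the scatter) and no change at the digits printed from compound 2 to compound 3 (within the scatter). Compound 4 `COc1ccccc1-c1cn2ccnc2c(-c2ccc3ncn(C4CCCCC4)c3c2)n1` differs by 2-methoxyphenyl in place of 4-bromophenyl on an aromatic carbon. Within the data shown here, no measured step covers a methoxy group, so the only guide is the step of a number 10.6 percentage points lower from compound 1 to compound 3 (beyond the scatter), which ran from a bare phenyl to a bromophenyl; removing the bromine might partly reverse it. A modest rise is therefore expected, with a number 6.7 percentage points higher from compound 3 to compound 4 (within the scatter). Compound 4 is estimated at 30%, within 15% to 45%.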

Compound 4, a percentage reported as inhibition, at one concentration (the size of the read-out at that concentration, not a potency): 25.7%
Beside the measured number, compound 4's estimate is 4.3 percentage points above it, and the stated range covers the measured number.
By their numbers in this assay, from the lowest: compounds 2, 3, 4 and 1 (each within the scatter of the next, the first and the last beyond it).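

The 2-methoxyphenyl group does not fall clearly with either side of the earlier gap between the bare phenyl and the two halogenated phenyls: the result is a number 2.4 percentage points higher from compound 3 to compound 4 (within the scatter), a number 2.4 percentage points higher from compound 2 to compound 4 (within the scatter) and a number 8.2 percentage points lower from compound 1 to compound 4 (within the scatter). Compound 4 therefore cannot be separated from any of the three earlier compounds, although compound 1 stays apart from compound 2 and compound 3. No available evidence explains this result. Still open, as far as these compounds go, is how an amine or a carboxylic acid on the phenyl ring would read at this position on the shared core.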